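The source may hold more compounds than are shown below. What is called first, only, known or untested is meant among the compounds shown, and "the series" means these compounds.

Compound 1 `CC(C)(C)c1ccc(-n2nc(-c3ccc(C(F)(F)F)cc3O)nc2-c2ccccc2O)cc1`: 81.1%
Compound 2 `N#Cc1ccc(-n2nc(-c3ccc(C(F)(F)F)cc3O)nc2-c2ccccc2O)cc1`: 98.9%

Going by the values given here, in a functional assay on PC-12 cells (Rattus norvegicus) for cytotoxicity, read by MTT assay, with stated times of 2 h and 24 h, tested at 10 uM (a lower number here means a weaker effect, a higher number a stronger effect of the compound at the concentration tested), compound 2 stands highest of the two numbers measured so far. Compound 3 `Oc1cc(C(F)(F)F)ccc1-c1nc(-c2ccccc2O)n(-c2ccc(F)cc2F)n1` differs from it by 2,4-difluorophenyl in place of 4-cyanophenyl on an aromatic nitrogen. Among the compounds with values here, only one measured step touches this same position, a number 17.8 percentage points higher from compound 1 to compound 2 (beyond the scatter), and it was modest; neither of those two groups matches the one now entering, so the direction of the new step is not fixed by what is known. Compound 3 is expected to remain strong in this assay, with a step of a number 10.9 percentage points lower from compound 2 to compound 3 (beyond the scatter). The estimate for compound 3 is 88%, within 70% to 100%.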

Compound 3, a percentage reported as activity, at one concentration (the size of the read-out at that concentration, not a potency): 97.9%
Beside the measured number, compound 3's estimate is 9.9 percentage points below it; the range from low to high includes it.
By their numbers in this assay, from the lowest: compound 1; then compounds 3 and 2 (each within the scatter of the next).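

In this assay, putting 2,4-difluorophenyl in place of 4-cyanophenyl on the aromatic nitrogen gives a number 1 percentage points lower from compound 2 to compound 3 (within the scatter) and so shows that two different substituted phenyl groups can read alike at this position. The same group in place of 4-(tert-butyl)phenyl gives a number 16.8 percentage points higher from compound 1 to compound 3 (beyond the scatter) and so leaves the tert-butyl compound as the only one of the three set apart. Nothing available here explains these numbers. Still open, as far as these compounds go, is whether an amine or a carboxylic acid on this phenyl ring would keep the read-out this high. From the compounds shown here alone, a simple alkyl chain in place of the ring is equally open.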